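This account rests on a few compounds, and the source may have more. Where it says the series, first, only, none or still open, it means among the compounds named here.

Measured so far in an ADME assay on Akata cells (Homo sapiens) for cytotoxicity, with a stated time of 7 days (a lower number here means that less compound is tolerated, a higher number that more compound is tolerated), all three reported as limits:
Compound 1 `CC(C)Nc1nc(N)nc2c1ncn2/C=C1/CC1(CO)CO` gives > 24000 nM
Compound 2 `CC(C)Sc1nc(N)nc2c1ncn2/C=C1/CC1(CO)CO` gives > 20000 nM
Compound 3 `CCCOc1nc(N)nc2c1ncn2/C=C1/CC1(CO)CO` gives > 20000 nM

Compound 3 gives a limit and no number: > 20000 nM. The series sits at two limits: the limit of > 20000 nM in this assay, at which 2 of the 3 values shown sit, and (the limit of > 24000 nM in this assay, at which 1 of the 3 values shown sits).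

The change under consideration leads to compound 4 `CCCCNc1nc(N)nc2c1ncn2/C=C1/CC1(CO)CO`, with butylamino in place of propoxy on an aromatic carbon.

The closest measured step is a step that the two limits leave unreadable from compound 1 to compound 3, which links propoxy to an amino-linked chain on the same carbon. The other two steps are a step that the two limits leave unreadable from compound 1 to compound 2 and a step that the two limits leave unreadable from compound 2 to compound 3. None of the three has a readable size, so none supplies a number to carry over to this change. Compound 1, with isopropylamino at this place, gives a limit, > 24000 nM. Compound 2, with isopropylsulfanyl there, also gives a limit, > 20000 nM.

On this basis no step beyond the scatter is expected in this assay, and no direction can be named. The estimated step is a step that the limit leaves unreadable from compound 3 to compound 4. A report as a limit again is the likelier outcome. For compound 4 the estimated value is 25000 nM, with an expected range from 10000 nM to 60000 nM.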

Compound 4, half-maximal cytotoxic concentration: > 24000 nM
Compound 4: only a limit was reported (the forecaster's own chance of this, stated with the estimate: 70%); the middle value does not contradict the limit.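

Compound 4 gives > 24000 nM, which is a limit. Among these compounds, compounds 1, 2 and 3 also give limits, so no step from any of them to compound 4 can be read. The compounds shown leave open whether butylamino, isopropylamino, isopropylsulfanyl and propoxy on this aromatic carbon differ at all in this assay.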